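The source may hold more compounds than are shown below. What is called first, only, known or untested is meant among the compounds shown, and "the series" means these compounds.

Working notes on the series, read out in a functional assay on NB-4 cells (Homo sapiens) for inhibition; on this read-out lower numbers stand for stronger inhibition and higher numbers for weaker inhibition. Compound 1 (`O=C(O)/C=C/c1ccc(-c2ccc(O)cc2)cc1`) gives 78700 nM, compound 2 (`O=C(O)/C=C/c1ccc(-c2ccc(O)c(CC3CCCCC3)c2)cc1`) gives 2200 nM and compound 3 (`CC(C)(C)c1cc(-c2ccc(/C=C/C(=O)O)cc2)ccc1O`) gives 42300 nM. Compound 3 therefore stands with compound 1, within the scatter of it, and far from compound 2. Tert-butyl in place of hydrogen leaves the number within the scatter, a 1.9-fold lower number from compound 1 to compound 3 (0.27 log units; within the scatter). Cyclohexylmethyl in place of hydrogen gives a large change, a 36-fold lower number from compound 1 to compound 2 (1.55 log units; beyond the scatter), and tert-butyl in place of cyclohexylmethyl reverses most of it, a 19-fold higher number from compound 2 to compound 3 (1.28 log units; beyond the scatter).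

Compound 4 (`O=C(O)/C=C/c1ccc(-c2ccc(O)c(-c3ccccc3)c2)cc1`) carries phenyl in place of tert-butyl on an aromatic carbon, ortho to a hydroxy group and meta to a large group: phenyl in place of tert-butyl on an aromatic carbon. For the measured compounds named here, no measured compound carries phenyl on this carbon, and only these three steps bear on the change. They show that the group at this place can move the number a long way, but that it does not always do so. Phenyl shares a six-membered ring with the cyclohexylmethyl of compound 2, though that ring is aromatic and the one in compound 2 is not. A moderate move toward compound 2 is therefore expected, well short of the full gap, as an estimated 2.8-fold lower number from compound 3 to compound 4 (0.45 log units; beyond the scatter). For compound 4 the estimated value in this assay is 15000 nM, with an expected range from 4000 nM to 50000 nM.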

Compound 4, half-maximal inhibitory concentration: 45300 nM
For compound 4 the middle estimate is 3.0-fold (0.48 log units) below the measured one; low and high end bracket the measured number.
By their numbers in this assay, from the lowest: compound 2; then compounds 3, 4 and 1 (each within the scatter of the next).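

In this assay, phenyl on this aromatic carbon does not separate from tert-butyl (a 1.1-fold higher number from compound 3 to compound 4 (0.03 log units; within the scatter)) or from hydrogen (a 1.7-fold lower number from compound 1 to compound 4 (0.24 log units; within the scatter)), so bulk at this place, whether a ring or a branched group, is not enough on these compounds to give a step beyond the scatter. For the compounds shown here, the six-membered ring that phenyl shares with cyclohexylmethyl does not carry the effect seen in compound 2 either (a 21-fold higher number from compound 2 to compound 4 (1.31 log units; beyond the scatter)), and that step is of the same order as the one for tert-butyl (a 19-fold higher number from compound 2 to compound 3 (1.28 log units; beyond the scatter)), which leaves compound 2 as the only compound of the four set apart from the rest. No measurement available here speaks to the origin of this difference.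

The compounds shown leave open whether the large step follows the methylene link, the non-aromatic ring, or the two together; benzyl, cyclohexyl and a straight hexyl chain on this carbon would separate these readings. They also leave open whether the hydroxy group is needed for the step, which an amine or a methoxy group in its place on the cyclohexylmethyl compound would test.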